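Methylpiperazinyl for Dimethylamino: Expected Solubility of Compound 4

This account rests on a few compounds, and the source may have more. Where it says the series, first, only, none or still open, it means among the compounds named here.

Of the compounds shown here, three of a shared core have been measured in a physicochemical assay (Homo sapiens) for solubility, with a stated time of 18 h, at pH 7.4; on this read-out higher numbers stand for higher solubility and lower numbers for lower solubility. Compound 1 `O=C1N=C(Nc2ccccc2)S/C1=C/c1ccc(N2CCNCC2)cc1` gives 1.68 ug/mL. Compound 2 `CN1CCN(c2ccc(/C=C3/SC(Nc4ccc(O)cc4)=NC3=O)cc2)CC1` gives 0.01 ug/mL. Compound 3 `CN(C)c1ccc(/C=C2/SC(Nc3ccc(Oc4ccccc4)cc3)=NC2=O)cc1` gives 0.01 ug/mL, level with compound 2 at the digits shown, the two together forming the lowest pair of the three, while compound 1 sits far above both, a gap well beyond the usual scatter. No two of these compounds differ in only one place, so no single-change step can be read off from the measured set.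

Compound 4 `CN1CCN(c2ccc(/C=C3/SC(Nc4ccc(Oc5ccccc5)cc4)=NC3=O)cc2)CC1` is the next compound to be measured. Compared with compound 3 it carries 4-methylpiperazin-1-yl in place of dimethylamino on an aromatic carbon. Compound 2 already carries the 4-methylpiperazin-1-yl group and gives 0.01 ug/mL, a number no different from that of compound 3 at the digits shown. On this basis the change is expected to bring no step beyond the scatter, and the expected step is no change at the digits printed from compound 3 to compound 4 (within the scatter). Compound 4 is therefore estimated to come out at about 0.01 ug/mL, with a range from 0.004 ug/mL to 0.05 ug/mL, and a real chance that the measurement returns only a limit rather than a number.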

Compound 4, solubility: 0.1 ug/mL
Beside the measured number, compound 4's estimate is 10-fold (1.00 log units) below it, outside the stated range (above it).
By their numbers in this assay, from the lowest: compounds 2 and 3 (each within the scatter of the next); then compound 4; then compound 1.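

In this assay, putting 4-methylpiperazin-1-yl in place of dimethylamino on this aromatic carbon, para to a large group, brings a 10-fold higher number from compound 3 to compound 4 (1.00 log units; beyond the scatter) and so shows that this position does respond to the exchange when the phenyl stays on the oxygen. Putting phenyl in place of hydrogen on the oxygen, with 4-methylpiperazin-1-yl held fixed, brings a 10-fold higher number from compound 2 to compound 4 (1.00 log units; beyond the scatter) and so gives a second single-change reading, one that runs in the same direction as the first. Compound 2 and compound 3 differ in two places, so their matching numbers could say nothing about either change alone, and no measurement shown here explains either step.

Going by these compounds, each step rests on a single pair of compounds, so it remains open whether the exchange would bring a similar step with a group such as methyl or a carboxylic acid on that oxygen. On these data alone, it also remains open whether a morpholin-4-yl group or a longer amine chain on the same aromatic carbon would shift the number in the same direction as 4-methylpiperazin-1-yl.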